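Amine exchange on the thiocarbonyl carbon: compound 3

A few compounds are considered here, and "the series" means these few. Any claim that something is new, unique, unknown or untested is made for them only; others in the source may bear on it.

compound 1 `CC1CCN(C(=S)SCc2ccc(C(=O)Nc3ccccc3N)cc2)CC1`: 32.7%
compound 2 `CN(Cc1ccncc1)C(=S)SCc1ccc(C(=O)Nc2ccccc2N)cc1`: 31.4%

In a functional assay on A-375 cells (Homo sapiens) for antiproliferative activity, read by CCK-8 assay, with a stated time of 72 h, tested at 2 uM (a higher number here means a stronger effect of the compound at the concentration tested, a lower number a weaker effect), compound 1 gives 32.7% and compound 2 gives 31.4%. Among the measured compounds shown here, compound 2 stands within the scatter of compound 1, and the one measured step, a number 1.3 percentage points lower from compound 1 to compound 2 (within the scatter), changed nothing beyond the scatter.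

Compound 3 `Nc1ccccc1NC(=O)c1ccc(CSC(=S)N2CCCC2)cc1` differs from compound 2 as follows: pyrrolidin-1-yl in place of methyl((pyridin-4-yl)methyl)amino on a thiocarbonyl carbon. For the measured compounds named here, the only step that bears on this, a number 1.3 percentage points lower from compound 1 to compound 2 (within the scatter), also exchanged the amine on the thiocarbonyl carbon and stayed within the scatter, so the expected step of a number 0.4 percentage points lower from compound 2 to compound 3 (within the scatter) is none beyond the scatter. Compound 3 is expected to give 31%, estimated between 19% and 43%.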

Compound 3, a percentage reported as inhibition, at one concentration (the size of the read-out at that concentration, not a potency): 30.2%
Compound 3: middle estimate off by 0.8 percentage points, on the high side, within the range that was stated.
By their numbers in this assay, from the lowest: compounds 3, 2 and 1 (each within the scatter of the next).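

Pyrrolidin-1-yl extends the exchange on the thiocarbonyl carbon to a smaller, five-membered non-aromatic ring, and in this assay the steps read a number 1.2 percentage points lower from compound 2 to compound 3 (within the scatter) and a number 2.5 percentage points lower from compound 1 to compound 3 (within the scatter). Across these three amines, neither 4-methylpiperidin-1-yl nor the six-membered aromatic ring of methyl((pyridin-4-yl)methyl)amino is needed to keep the read-out within the scatter. No measurement here offers an explanation for this flat result.

Still open, going by these compounds, is whether any amine at this carbon separates from the three, for example morpholin-4-yl or a piperazine with a free amine. Also open, on these data alone, is whether a carbonyl can replace the thiocarbonyl.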